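A few compounds are considered here, and "the series" means these few. Any claim that something is new, unique, unknown or untested is made for them only; others in the source may bear on it.

Of the compounds shown here, three built on one shared core have been measured in a functional assay on PANC-1 cells (Homo sapiens) for inhibition, read by MTT assay, with a stated time of 24 h, tested at 10 uM; a higher number here means more inhibition at the concentration tested (going by the name of the read-out), a lower number less inhibition. Compound 1 `CC(C)=CCC1Cc2c(OCc3ccccc3)cc(=O)n(CCCO)c2CC1(C)C` carries a benzyl group on the ring oxygen and gives 11.1%. Compound 2 `CC(C)=CCC1Cc2c(OC(=O)Nc3cccc(C(F)(F)F)c3)cc(=O)n(CCCO)c2CC1(C)C` carries a carbamate on that oxygen instead, and in this assay compound 2 gives 0%. Compound 3 `CC(C)=CCC/C(C)=C/CC1Cc2c(OCc3ccccc3)cc(=O)n(CCCO)c2CC1(C)C` keeps the benzyl group, and in this assay compound 3 gives 1.5%. On the numbers as they stand, compound 3 is the second highest of the three, but its gaps to compound 2 and to compound 1 both lie within the scatter, so none of the three can be separated from the others.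

The step to compound 4 `CC(C)=CCC/C(C)=C/CC1Cc2c(OC(=O)Nc3ccc(F)cc3)cc(=O)n(CCCO)c2CC1(C)C` replaces the benzyl group: (4-fluorophenyl)carbamoyl in place of benzyl on an oxygen on an aromatic ring. Among the measured compounds shown here, no measured step matches this exactly. The nearest pairing is compound 1 against compound 2, where a different carbamate sits on the same oxygen; compound 1 gives 11.1% while compound 2 gives 0%, a gap within the scatter. For the measured compounds named here, the one measured step, a number 9.6 percentage points lower from compound 1 to compound 3 (within the scatter), concerns the chain rather than the oxygen substituent and was within the scatter as well. Accordingly, the estimated step of a number 0.5 percentage points higher from compound 3 to compound 4 (within the scatter) is expected to stay within the scatter. Compound 4 is expected to give 2%, with a range from 0% to 12%.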

Compound 4, a percentage reported as inhibition, at one concentration (the size of the read-out at that concentration, not a potency): 6.2%
Compound 4: middle estimate off by 4.2 percentage points, on the low side; measured number inside the range.
By their numbers in this assay, from the lowest: compounds 2, 3, 4 and 1 (each within the scatter of the next, the first and the last beyond it).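

With the chain of compound 3 held fixed, this is the only listed step that changes the group on the oxygen alone, and in this assay putting (4-fluorophenyl)carbamoyl in place of benzyl gives a number 4.7 percentage points higher from compound 3 to compound 4 (within the scatter) and so cannot be told apart from no difference. The swap adds a nitrogen, a carbonyl, a fluorine and a hydrogen-bond donor while keeping one six-membered aromatic ring, so this position accepts quite a different linking group without a readable shift in inhibition at the concentration tested. Nothing available explains this outcome or says what the added atoms do in the cells.

From the compounds shown here alone, all four numbers sit low on this scale, so it remains open whether any group on this oxygen, such as an acetyl, a chain ending in an amine or one ending in a carboxylic acid, would lift inhibition clearly beyond the scatter. Also open, going by these compounds, is whether a different group in place of the 3-hydroxypropyl chain on the ring nitrogen, such as a shorter ethyl or a chain ending in a carboxylic acid, would do so.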